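The source may report more compounds than this note shows. Statements on the series, on what has been measured and on what is new or still open speak of the compounds shown alone.

Measured so far:
compound 1, `CC(C)C(/C=C1\CCNC1=O)c1ccc(-c2ccc3cccc(F)c3c2)[nH]c1=O`: 0.713 h
compound 2, `CCn1ncc2c(F)cc(-c3ccc(C(CC)(CC)c4nncn4C)c(=O)[nH]3)cc21`: 2.67 h

Both numbers come from an ADME assay on microsomes from liver (Homo sapiens) for metabolic stability; a higher number here means that the compound lasts longer, a lower number that the compound disappears faster. Within this pair compound 1 stands lowest; the nearest and only other number, that of compound 2, is higher by a margin that lies beyond the usual scatter of repeated measurements. Among the measured compounds shown here, nothing more can be read from these two, since they differ in many places at once and no single-point step between them exists.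

The compound not yet measured is compound 3, `CC(C)C(Cc1nnc[nH]1)c1ccc(-c2ccc3cccc(F)c3c2)[nH]c1=O`. It departs from compound 1 in one place: a group of 6 heavy atoms (3 carbon, 3 nitrogen; one five-membered aromatic ring with 3 hetero atoms) in place of a group of 7 heavy atoms (5 carbon, 1 nitrogen, 1 oxygen; one five-membered non-aromatic ring with 1 hetero atom), on a saturated chain carbon bound to an aromatic carbon and a saturated chain carbon. For the measured compounds named here, with no measured step of this kind available, the expectation for compound 3 can rest only on the value of compound 1 and the nature of the change. Compound 3 is expected to come out near 1 h, with an estimated range from 0.4 h to 2.5 h. The expected step of a 1.4-fold higher number from compound 1 to compound 3 (0.15 log units; within the scatter) is small and, if anything, upward, and it may well fall within the scatter rather than beyond it.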

Compound 3, half-life: 0.307 h
Beside the measured number, compound 3's estimate is 3.3-fold (0.51 log units) above it; the whole stated range lies above it.
By their numbers in this assay, from the lowest: compound 3; then compound 1; then compound 2.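

At the saturated chain carbon bound to an aromatic carbon and a saturated chain carbon, exchanging the five-membered non-aromatic ring group for (4H-1,2,4-triazol-3-yl)methyl gives, in this assay, a 2.3-fold lower number from compound 1 to compound 3 (0.37 log units; beyond the scatter), a modest change but one that lies beyond the scatter. Among the compounds shown here, this is the only step here that differs in one place, so it shows what the earlier pair could not: on this shared core, the group at this position has a readable bearing on the half-life, and this exchange moves it downward. No measured information bears on the reason for this step.

The step changes several things at once, including the ring, its aromatic character and the double bonds outside aromatic rings, so the compounds shown leave open which of these goes with the lower number. They also leave open how this position would respond to other groups, such as an open-chain amide, a carboxylic acid, an amine or a plain ethyl chain, and whether the same exchange would give a step of similar size on a different core.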